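Working notes on a single-methyl change in this series

This account rests on a few compounds, and the source may have more. Where it says the series, first, only, none or still open, it means among the compounds named here.

Measured so far: compound 1 `CC(C)(CCCOc1ccc(-c2ccc(Cl)cc2)cc1)CN1CCN(c2ccncc2)C1=O` with 20000 nM in an ADME assay on cells (Homo sapiens) for cytotoxicity; on this read-out higher numbers stand for lower toxicity in this test and lower numbers for higher toxicity in this test. Compound 2 `O=C1N(CCC2(CCOc3ccc(-c4ccc(Cl)cc4)cc3)CCCCC2)CCN1c1ccncc1` reaches only the limit of this assay, > 25000 nM. Compound 3 `Cc1nc(-c2ccc(OCCC(C)CCN3CCN(c4ccncc4)C3=O)cc2)no1` likewise stops at a limit of this assay, > 6250 nM.

Going by the values given here, compound 1 thus stands as the only actual number in this assay; the two other values are limits (the limit of > 25000 nM in this assay, at which 1 of the 3 values shown sits, and (the limit of > 6250 nM in this assay, at which 1 of the 3 values shown sits)), so where compound 2 and compound 3 sit relative to compound 1 cannot be told beyond that.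

Compound 4 `CC(CCCOc1ccc(-c2ccc(Cl)cc2)cc1)CN1CCN(c2ccncc2)C1=O` differs from compound 1 by hydrogen in place of methyl on a saturated chain carbon bound to three saturated chain carbons. Among the compounds with values here, no measured pair in this assay carries this change, so its size is unknown. Loss of one methyl on the chain is expected to move the read-out in this assay by no more than the scatter, in no firm direction; the expected step is no change at the digits printed from compound 1 to compound 4 (within the scatter). Compound 4 is therefore estimated at 20000 nM, with a range from 10000 nM to 40000 nM.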

Compound 4, half-maximal cytotoxic concentration: > 25000 nM
Compound 4: only a limit was reported; the forecaster's own chance of this, stated with the estimate: 40%; middle value at least 1.2-fold (0.09 log units) away from the limit.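

Hydrogen in place of methyl on a saturated chain carbon bound to three saturated chain carbons gives the first pair in this series that differs in one place, and in this assay the pair reads as an at least 1.2-fold higher number from compound 1 to compound 4 (0.09 log units; that floor lies within the scatter) with no fall in the read-out. Compound 4 carries a limit, not a number: the limit of > 25000 nM in this assay, at which 2 of the 4 values shown sit. The second methyl at this carbon is therefore not needed to keep the read-out at this level, although the floor of the step gives no firm rise.

As far as these compounds go, how far compound 4 really sits from compound 1 stays open, as the true size of the step cannot be read from a limit. The compounds shown also leave open how an ethyl group or an amine at this chain carbon would read in this assay.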